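The source may report more compounds than this note shows. Statements on the series, on what has been measured and on what is new or still open speak of the compounds shown alone.

Working notes on the series. Compound 1 `O=C(Cn1cc(COc2ccc3c(c2)CCC3)nn1)Nc1ccc(Br)cc1` carries the shared core with an amide-linked 4-bromophenyl group; in an ADME assay on HEK293 cells (Homo sapiens) for inhibition, read by MTT assay, with a stated time of 48 h, tested at 25 uM (on this read-out lower numbers stand for less inhibition and higher numbers for more inhibition at the one concentration tested (going by the name of the read-out)), compound 1 is recorded as "not determined" (no result reported), so it cannot be placed on the numbers. Within the data shown here, compound 2 `Fc1ccccc1-n1cc(COc2ccc3c(c2)CCC3)nn1` is the only member with a number: in this assay compound 2 gives 21%. Compound 3 `O=[N+]([O-])c1cccc(-n2cc(COc3ccc4c(c3)CCC4)nn2)c1` likewise is recorded as "not determined" (no result reported) in this assay. Compound 4 `COc1ccccc1NC(=O)Cn1cc(COc2ccc3c(c2)CCC3)nn1` differs from compound 1 by 2-methoxyphenyl in place of 4-bromophenyl on an amide-type nitrogen. Among the measured compounds shown here, with no measured step between any two compounds, the size of the change from compound 1 to compound 4 in this assay cannot be read from the data; no step beyond the usual scatter is expected in either direction. Going by compound 2 alone, compound 4 is expected to give about 20% in this assay, within 5% to 40%.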

Compound 4, a percentage reported as inhibition, at one concentration (the size of the read-out at that concentration, not a potency): 23.4%
Beside the measured number, compound 4's estimate is 3.4 percentage points below it; the range from low to high includes it.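

No new step can be read between compound 1 and compound 4 in this assay. The compounds shown leave open how 4-bromophenyl and 2-methoxyphenyl on the amide-type nitrogen compare in this assay. No evidence on this result is available.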